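Methyl additions on the chain at the core nitrogen

The compounds below may be only part of what the source reports. "The series", "measured", "known", "first", "only" and "open" are said of these compounds alone.

Measured so far, in a functional assay on the whole organism for antagonist activity, with Rattus norvegicus as the target; on this read-out lower numbers stand for an effect already at smaller amounts and higher numbers for an effect only at larger amounts of compound:
compound 1 `CCCn1cnc2c(NC3CC3)ncnc21`: 6 mg/kg
compound 2 `CCCCn1cnc2c(NC3CC3)ncnc21`: 18 mg/kg
compound 3 `O=CN(c1ncnc2c1ncn2CC1CC1)C1CC1`: 8 mg/kg

Going by the values given here, the only single-point step among the measured compounds is methyl in place of hydrogen on a saturated chain carbon, three bonds along the chain from an aromatic nitrogen, which gives a 3.0-fold higher number from compound 1 to compound 2 (0.48 log units; beyond the scatter). Compound 3 differs from compound 1 in more than one place; the difference between the two cores is not broken down here. The values of compound 3 and compound 1 lie within the scatter of each other, while compound 2 stands beyond the scatter above compound 3.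

Compound 4 `CC(C1CC1)n1cnc2c(N(C=O)C3CC3)ncnc21` is not yet measured. Relative to compound 3 it carries methyl in place of hydrogen on a saturated chain carbon bound to an aromatic nitrogen and a saturated ring carbon. Among the compounds with values here, this is the same kind of change as the one from compound 1 to compound 2, but the place differs: there the methyl enters three bonds along the chain from an aromatic nitrogen, here it enters on a saturated chain carbon bound to an aromatic nitrogen and a saturated ring carbon. Within the data shown here, only one such step is measured, so its transfer is uncertain. Compound 4 is expected to show a step of a 2.0-fold higher number from compound 3 to compound 4 (0.30 log units; within the scatter), a rise of the same kind as a 3.0-fold higher number from compound 1 to compound 2 (0.48 log units; beyond the scatter) but taken as smaller. Compound 4 is therefore estimated at 16 mg/kg, with a range from 6 mg/kg to 40 mg/kg.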

Compound 4, dose for half-maximal effect: 2.5 mg/kg
Estimate against measurement, compound 4: 6.4-fold (0.81 log units) above; the measured number lies below the stated range.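

In this assay the methyl on the cyclopropylmethyl chain gives a 3.2-fold lower number from compound 3 to compound 4 (0.51 log units; beyond the scatter) and so runs against the rise seen on the core of compound 1, which was a 3.0-fold higher number from compound 1 to compound 2 (0.48 log units; beyond the scatter) in the same assay. This change therefore cannot be carried from one core to the other as a fixed step, not even in its direction: the same change on two cores in this assay, a 3.0-fold higher number (0.48 log units; beyond the scatter) from compound 1 to compound 2 and a 3.2-fold lower number (0.51 log units; beyond the scatter) from compound 3 to compound 4, 9.6-fold (0.98 log units) apart, beyond the scatter of two such steps

The two steps differ in the core and also in the place of the methyl, and each is measured only once, so these compounds do not show whether the core, the place or both set the reversal.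

On these data alone, it remains open what the same methyl does on the saturated chain carbon bound to an aromatic nitrogen when the core of compound 1 carries it. Also open, as far as these compounds go, is whether an ethyl group on that same carbon, in place of the methyl, would follow the step seen with the 1-cyclopropylethyl chain.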